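Cyclopentyl to isopropyl on the ketone side chain

A few compounds are considered here, and "the series" means these few. Any claim that something is new, unique, unknown or untested is made for them only; others in the source may bear on it.

In an assay on HEK293 cells for positive allosteric modulation of metabotropic glutamate receptor 3 (Rattus norvegicus), read by thallium flux, with a stated time of 2.5 min (on this read-out lower numbers stand for smaller maximal responses and higher numbers for larger maximal responses), compound 1 `Cc1c(OCCCCOc2ccccc2C(=O)O)ccc(C(=O)CC2CCCC2)c1C` gives 28%. Among the compounds with values here, compound 2 `Cc1c(OCCCCOc2ccc(C(=O)O)cc2)ccc(C(=O)CC2CCCC2)c1C` gives 12.2%, the lowest of the two numbers so far, set apart by the step of a number 15.8 percentage points lower from compound 1 to compound 2 (beyond the scatter). Compound 3 `Cc1c(OCCCCOc2ccc(C(=O)O)cc2)ccc(C(=O)CC(C)C)c1C` introduces the change (isopropyl in place of cyclopentyl on a saturated chain carbon bound to a carbonyl carbon). Within the data shown here, no measured step bears on this change: the only known step concerns the carboxyphenyl, not the group on the saturated chain carbon bound to the carbonyl carbon. The expected step is therefore a number 0.8 percentage points higher from compound 2 to compound 3 (within the scatter), within the scatter. Compound 3 is estimated at 13%, with a range from 2% to 30%.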

Compound 3, largest response reached (reported as percent of maximum), in percent of the reference or control that the assay uses: 16.6%
Compound 3: middle estimate off by 3.6 percentage points, on the low side, and the stated range covers the measured number.
By their numbers in this assay, from the lowest: compounds 2 and 3 (each within the scatter of the next); then compound 1.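

Isopropyl in place of cyclopentyl on a saturated chain carbon bound to a carbonyl carbon gives a number 4.4 percentage points higher from compound 2 to compound 3 (within the scatter) in this assay on the 4-carboxyphenyl series. Within the data shown here, at this place, then, going from 5 to 3 heavy atoms and losing the five-membered ring leaves the two numbers within the scatter, a first reading on this position. No evidence at hand accounts for this result.

Open, as far as these compounds go, is whether the same change holds with the 2-carboxyphenyl of compound 1, at 28% in this read-out. Also open, from the compounds shown here alone, is how a longer chain or an amine would read at this place.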